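Cytotoxicity notes on compounds 1 to 3

The source may hold more compounds than are shown below. What is called first, only, known or untested is meant among the compounds shown, and "the series" means these compounds.

Compound 2 `O=c1nc(-c2ccccc2)c2cc(-c3cc[nH]n3)ccc2[nH]1` stands only at a limit in an ADME assay on THP-1 cells (Homo sapiens) for cytotoxicity, read by MTT assay, with a stated time of 72 h; a lower number here means that less compound is needed, a higher number that more compound is needed for the effect: compound 2 gives > 50000 nM, which is a limit of the assay and not a number. Compound 1 `O=c1nc(-c2ccccc2)c2cc(-c3ccc(F)cc3)ccc2[nH]1` likewise returns a limit in this assay, > 50000 nM, again not a number. For the measured compounds named here, the one measured step, a step that the two limits leave unreadable from compound 1 to compound 2, therefore cannot be read, and the limit of > 50000 nM in this assay, at which 2 of the 2 values shown sit, is all the evidence the series offers so far.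

Compound 3 `Cn1nccc1-c1ccc2[nH]c(=O)nc(-c3ccccc3)c2c1` differs from compound 2 by 1-methyl-1H-pyrazol-5-yl in place of 1H-pyrazol-3-yl on an aromatic carbon. Going by the values given here, no readable measured step bears on this change; the single step available is the unreadable one between the first two compounds. With both measured values sitting at the limit, as the limit of > 50000 nM in this assay, at which 2 of the 2 values shown sit, shows, no step beyond the scatter can be expected in this assay in either direction, and the expected outcome for compound 3 is once more a limit rather than a number. The estimate for compound 3 is 50000 nM, with a range from 20000 nM to 150000 nM. The step this estimate implies, a number no higher from compound 2 to compound 3 (the limit leaves the size open), is expected to be nil within the scatter.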

Compound 3, half-maximal effective concentration: > 50000 nM
Compound 3: no number, only a limit; the forecaster's own chance of this, stated with the estimate: 80%; the middle value sits exactly at the limit.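

In this assay compound 3 gives > 50000 nM, a limit of the assay and not a number. No new step can be read from compound 3 to compound 1 or compound 2: the limit of > 50000 nM in this assay, at which 3 of the 3 values shown sit. The compounds shown leave open whether any substituent on the shared core would give a readable number in this assay.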